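Urea series notes: from compound 1 toward compound 4

The source may hold more compounds than are shown below. What is called first, only, known or untested is meant among the compounds shown, and "the series" means these compounds.

In a functional assay on A375P cells (Homo sapiens) for antiproliferative activity (a lower number here means a stronger inhibitor, a higher number a weaker inhibitor), compound 1 `CC(=O)Nc1cc(NC(=O)Nc2ccccc2Cl)ccc1C` gives > 30000 nM, which is a limit of the assay and not a number. Compound 3 `CC(=O)Nc1cc(NC(=O)Nc2cccc(Oc3ccccc3)c2)ccc1C` likewise gives > 30000 nM, again a limit. Compound 2 `CC(=O)Nc1cc(NC(=O)Nc2cc(Cl)cc(Cl)c2)ccc1C` gives 561 nM. Compound 1 thus stands at the limit of > 30000 nM in this assay, at which 2 of the 3 values shown sit, with compound 2 the only one of the three that returns a number. Compound 4 `CC(=O)Nc1cc(NC(=O)Nc2ccc(Cl)nc2)ccc1C` is still to be measured in this assay; its change from compound 1 is 6-chloropyridin-3-yl in place of 2-chlorophenyl on an amide-type nitrogen. Among the measured compounds shown here, no measured pair differs in one place, so the step size is unknown; a modest move toward a stronger inhibitor is expected, but not beyond the scatter with any confidence. Compound 4 is expected to give 20000 nM, in the range 4000 nM to 100000 nM. The expected step is an at least 1.5-fold lower number from compound 1 to compound 4 (0.17 log units; that floor lies within the scatter).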

Compound 4, half-maximal inhibitory concentration: 1100 nM
Compound 4: middle estimate off by 18-fold (1.26 log units), on the high side, and the stated range ends above it.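

Among the compounds shown here, replacing 2-chlorophenyl with 6-chloropyridin-3-yl on the amide-type nitrogen gives an at least 27-fold lower number from compound 1 to compound 4 (1.43 log units; beyond the scatter), the first step that can be read, so activity at this position depends strongly on the aromatic group carried there. Compound 1 sits at a limit and not a number, so this step is only a floor and its true size stays open: the limit of > 30000 nM in this assay, at which 2 of the 4 values shown sit.

The compounds shown leave open whether the ring nitrogen or the changed chlorine place accounts for the step, since both change together. On these data alone, how an amine or a carboxylic acid in place of that chlorine would read in this assay also stays open.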